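Deoxyribonucleoside series: isoxazole side chain, aryl to alkyl

A few compounds are considered here, and "the series" means these few. Any claim that something is new, unique, unknown or untested is made for them only; others in the source may bear on it.

Measured so far:
compound 1, `CC(=O)OC[C@H]1O[C@@H](n2cc(-c3cn(Cc4ccccc4)nn3)c(=O)[nH]c2=O)C[C@@H]1OC(C)=O`: 102%
compound 2, `CC(C)(C)c1ccc(Cn2cc(-c3cn([C@H]4C[C@H](O)[C@@H](CO)O4)c(=O)[nH]c3=O)nn2)cc1`: 106%
compound 3, `CCCCc1ccc(-c2cc(-c3cn([C@H]4C[C@H](OC(C)=O)[C@@H](COC(C)=O)O4)c(=O)[nH]c3=O)on2)cc1`: 72.2%

In a functional assay on MDA-MB-231 cells (Homo sapiens) for cytotoxicity, read by sulforhodamine B assay, tested at 10 uM (on this read-out lower numbers stand for less inhibition and higher numbers for more inhibition at the one concentration tested (going by the name of the read-out)), compound 1 and compound 2 give numbers that lie within the scatter of each other, so no order between them is read. Compound 3 stands lowest of the three in this assay: its gap to compound 1 is the smaller one and its gap to compound 2 the larger, and both are beyond the scatter.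

The next compound is compound 4, `CCCCCc1cc(-c2cn([C@H]3C[C@H](OC(C)=O)[C@@H](COC(C)=O)O3)c(=O)[nH]c2=O)on1`. Relative to compound 3 it changes in one place: pentyl in place of 4-butylphenyl on an aromatic carbon. Going by the values given here, no pair of measured compounds differs in only this way, so no measured step of this kind is at hand, and the three numbers give no direct guide to its size.

Given that, a modest downward step is expected, not a large one. The expected step in this assay is a number 10.2 percentage points lower from compound 3 to compound 4 (beyond the scatter), of a size that may or may not clear the scatter. Compound 4 is expected to give an estimated 62% in this assay, with a range from 35% to 88%.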

Compound 4, a percentage reported as inhibition, at one concentration (the size of the read-out at that concentration, not a potency): 91.5%
For compound 4 the middle estimate is 29.5 percentage points below the measured one; measured number outside the range, above it.
By their numbers in this assay, from the lowest: compound 3; then compound 4; then compounds 1 and 2 (each within the scatter of the next).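

In this assay, the aromatic carbon next to the ring nitrogen, on the five-membered aromatic ring with 1 nitrogen and 1 oxygen, now has its first measured step: pentyl in place of 4-butylphenyl gives a number 19.3 percentage points higher from compound 3 to compound 4 (beyond the scatter) on an otherwise unchanged structure. In this one pair, the six-membered aromatic ring of carbon only is not required for the read-out at the single concentration tested, and the group with 5 heavy atoms goes with the higher number, though a single pair cannot separate removal of the ring from the change in group size. Nothing at hand accounts for the size or direction of this step.

Open questions are whether a longer chain than pentyl, a shorter chain such as propyl, or a chain ending in an amine or a carboxylic acid would raise or lower the number at this position. Also open, from the compounds shown here alone, is whether the same exchange gives a similar step on a core carrying free hydroxyl groups in place of the two acetate esters, and whether such single-concentration differences carry over to potency.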